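A few compounds are considered here, and "the series" means these few. Any claim that something is new, unique, unknown or untested is made for them only; others in the source may bear on it.

Of the compounds shown here, three built on one shared core have been tested. Compound 1 `Oc1cc(-c2ccccc2)nc2c(O)cccc12` in a functional assay on L1210 (1565) cells (Mus musculus) for cytotoxicity (on this read-out lower numbers stand for an effect already at smaller amounts and higher numbers for an effect only at larger amounts of compound), gives only a limit of the assay, > 10 ug/mL. Compound 2 `Oc1cc(-c2ccccc2)nc2cc(F)ccc12` in this assay gives 0.16 ug/mL. Compound 3 `CCCCOc1cc(-c2ccccc2)nc2ccccc12` again reaches only a limit of the assay, > 10 ug/mL. So compound 3 stands at the limit of > 10 ug/mL in this assay, at which 2 of the 3 values shown sit, not at a measured number. Compound 4 `CC(C)Oc1cc(-c2ccccc2)nc2ccccc12` has not been measured yet. It differs from compound 3 by isopropyl in place of butyl on an oxygen on an aromatic ring. Within the data shown here, no pair of measured compounds shows what such a change does in this assay, so the expectation rests on compound 3 alone. The step that the limit leaves unreadable from compound 3 to compound 4 expected here is none beyond the scatter. Compound 4 is therefore expected to sit at about 15 ug/mL, within a range from 5 ug/mL to 40 ug/mL.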

Compound 4, half-maximal effective concentration: > 10 ug/mL
Compound 4 was reported as a limit; the forecaster's own chance of this, stated with the estimate: 70%; the middle value is on the limit's open side.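

Among these compounds, compound 3 and compound 4 both reach only a limit in this assay, so no step from butyl to isopropyl can be read. The compounds shown leave open whether this change alters the cytotoxic effect at all.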